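Trifluoromethyl for Methoxy on the Aryl Ring

The source may report more compounds than this note shows. Statements on the series, on what has been measured and on what is new or still open speak of the compounds shown alone.

Within the data shown here, compound 2, `COc1cccc(-c2cc3c(n2-c2ccc(O)c(C(=O)O)c2)CCCC3)c1`, holds the only plain number here: in a functional assay on the whole organism (strain Wistar) for inhibition, with Rattus norvegicus as the target, read by paw edema, with stated times of 30 min and 3 h, at a dose of 200 mg/kg by the oral route (on this read-out lower numbers stand for less inhibition and higher numbers for more inhibition at the one dose given (going by the name of the read-out)), compound 2 gives 20%. Compound 1, `O=C(O)c1cc(-n2c(-c3ccccc3)cc3c2CCCC3)ccc1O`, gives >= 60%, a limit of the assay rather than a number, as the limit of >= 60% in this assay, at which 1 of the 2 values shown sits, notes. Among the measured compounds shown here, the one measured step, a number at least 40 percentage points lower from compound 1 to compound 2 (beyond the scatter), came with a methoxy in place of hydrogen on an aromatic carbon. Compound 3, `O=C(O)c1cc(-n2c(-c3cccc(C(F)(F)F)c3)cc3c2CCCC3)ccc1O`, differs from compound 2 by trifluoromethyl in place of methoxy on an aromatic carbon. For the measured compounds named here, no measured step swaps one such group for another, so only a modest change is expected, a number 10 percentage points higher from compound 2 to compound 3 (within the scatter). Compound 3 is estimated at 30%, between 10% and 55%.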

Compound 3, a percentage reported as inhibition, in the whole organism at one dose (the size of the read-out at that dose, not a potency): 20%
For compound 3 the middle estimate is 10 percentage points above the measured one, and the stated range covers the measured number.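

In this assay, the swap on this aromatic carbon, meta to a large group, gives no change at the digits printed from compound 2 to compound 3 (within the scatter), so the two groups cannot be told apart here. Compound 1, with hydrogen at this place, carries a limit of the assay rather than a number, >= 60%. Trifluoromethyl in place of that hydrogen also brings a number at least 40 percentage points lower from compound 1 to compound 3 (beyond the scatter), so the large fall seen earlier is not particular to methoxy. From the compounds shown here alone, whether a chlorine or an amine on this carbon would read closer to compound 1 stays open, as does whether either group would act the same on another carbon of this ring.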